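Clearance step from compound 1 to compound 4

The compounds below may be only part of what the source reports. "The series", "measured", "known", "first", "only" and "open" are said of these compounds alone.

Compound 1 (`Cc1ccc(NC(=O)[C@H](CC2CCCC2)n2cnc(C(F)(F)F)c2)nc1`) is the starting point in an in vitro ADME assay on microsomes from liver (Homo sapiens) for metabolic stability; on this read-out higher numbers stand for fast clearance and lower numbers for slow clearance. Compound 1 reads > 120 mL/min/kg as a limit of the assay and not a number. Compound 2 (`O=C(O)c1ccc(NC(=O)[C@H](CC2CCCC2)n2cnc(C(F)(F)F)c2)nc1`) reads < 8 mL/min/kg as a limit as well. Compound 3 (`O=C(O)Cn1ccc(NC(=O)[C@H](CC2CCCC2)n2cnc(C(F)(F)F)c2)n1`) reads < 8 mL/min/kg as a limit too.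

Compound 4 (`O=C(O)c1cnc(NC(=O)[C@H](CC2CCCC2)n2cnc(C(F)(F)F)c2)cn1`) departs from compound 1 in one place (5-carboxypyrazin-2-yl in place of 5-methylpyridin-2-yl on an amide-type nitrogen) with 5-carboxypyrazin-2-yl in place of 5-methylpyridin-2-yl on an amide-type nitrogen.

Going by the values given here, two measured steps bear on this change. Among the compounds with values here, compound 2 is the closest precedent, with an at least 15-fold lower number from compound 1 to compound 2 (1.17 log units; beyond the scatter) as a large step beyond the scatter. Compound 3 points the same way, with an at least 15-fold lower number from compound 1 to compound 3 (1.17 log units; beyond the scatter) as a step of the same large size. Neither of these two carboxy-bearing compounds goes against the trend, although two compounds are a thin basis. The comparison of the two gives a step that the two limits leave unreadable from compound 2 to compound 3 and so adds nothing on size.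

A large fall in clearance is therefore expected, and the estimated step is an at least 17-fold lower number from compound 1 to compound 4 (1.23 log units; beyond the scatter) in the same direction as both precedents. Compound 4 is estimated at 7 mL/min/kg in this assay with an expected range from 3 mL/min/kg to 18 mL/min/kg and a fair chance of a reading that is only a limit.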

Compound 4, clearance: < 8 mL/min/kg
Compound 4: no number, only a limit (the forecaster's own chance of this, stated with the estimate: 70%); the middle value is on the limit's open side.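

In this assay, replacing 5-methylpyridin-2-yl with 5-carboxypyrazin-2-yl on the amide-type nitrogen gives an at least 15-fold lower number from compound 1 to compound 4 (1.17 log units; beyond the scatter). This adds a third carboxy-bearing group at this place, and the first on a six-membered aromatic ring with 2 hetero atoms; among the compounds shown, compound 2, compound 3 and compound 4 all go the same way and none of the carboxy-bearing compounds goes against this. The steps among these three compounds cannot be read, and they cannot be ranked in this assay because each reading stops at the same limit: the limit of < 8 mL/min/kg in this assay, at which 3 of the 4 values shown sit.

Still open, as far as these compounds go, is how 5-methylpyrazin-2-yl, or a methyl ester or primary amide in place of the carboxylic acid of compound 4, would read on the same amide-type nitrogen, which would help separate the part played by the ring from that of the carboxylic acid. Also open is the true size of any step from compound 1, whose reading is likewise a limit and not a number: the limit of > 120 mL/min/kg in this assay, at which 1 of the 4 values shown sits.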